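Halogen swap on the aryloxy ring of compound 3

The source may report more compounds than this note shows. Statements on the series, on what has been measured and on what is new or still open speak of the compounds shown alone.

Three members of the series have been measured in a functional assay on HepG2 cells (Homo sapiens) for antiproliferative activity, read by MTT assay, with a stated time of 72 h; on this read-out lower numbers stand for stronger inhibition and higher numbers for weaker inhibition. Compound 1 `Cc1nn(C)c(Oc2ccc(Cl)cc2)c1/C=N\CCCCCOc1cc2oc(=O)cc(C)c2cc1Cl` gives 15300 nM in this assay, and compound 2 `Cc1ccc(Oc2c(/C=N\CCCCCOc3cc4oc(=O)cc(C)c4cc3Cl)c(C)nn2C)cc1` gives 10300 nM. Among the measured compounds shown here, the single one-point comparison among measured members, a 1.5-fold lower number from compound 1 to compound 2 (0.17 log units; within the scatter), concerns methyl in place of chloro on an aromatic carbon and stays within the scatter. Compound 3 `Cc1nn(C)c(Oc2ccccc2F)c1/C=N\CCCCCCOc1cc2oc(=O)cc(C)c2cc1Cl` gives only a limit in this assay, > 25000 nM. Its value is the one that sits at the limit of > 25000 nM in this assay, at which 1 of the 3 values shown sits, so compound 3 stands without a number of its own, at the weak end of what this assay reports. Compound 4 `Cc1nn(C)c(Oc2ccccc2Br)c1/C=N\CCCCCCOc1cc2oc(=O)cc(C)c2cc1Cl` differs from compound 3 by bromo in place of fluoro on an aromatic carbon, ortho to a large group. For the measured compounds named here, no measured step involves a halogen exchange at this place, and the one step measured was within the scatter, so no step beyond the scatter is expected in this assay in either direction; compound 4 is expected to remain near a limit. For compound 4 the estimate is 30000 nM, with a range from 12000 nM to 80000 nM, which corresponds to an expected step that the limit leaves unreadable from compound 3 to compound 4.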

Compound 4, half-maximal inhibitory concentration: 24200 nM
Estimate against measurement, compound 4: 1.2-fold (0.09 log units) above; the measured number falls inside the stated range.
By their numbers in this assay, from the lowest: compounds 2, 1 and 4 (each within the scatter of the next, the first and the last beyond it). At a limit, above all of these: compound 3.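

Among the compounds shown here, compound 3 carries only a limit in this assay, so the exchange of 2-fluorophenoxy to 2-bromophenoxy is the first at this place to yield a measured number, in compound 4. The change reads as an at least 1.0-fold lower number from compound 3 to compound 4 (0.01 log units; that floor lies within the scatter), which is a floor rather than a size, and it rests on a limit: the limit of > 25000 nM in this assay, at which 1 of the 4 values shown sits. This floor therefore shows no effect of the exchange beyond the scatter, yet it does not rule one out.

On these data alone, how far compound 3 truly lies from compound 4 stays open, and so does whether the halogen on this aromatic carbon matters at all. A methoxy group, a trifluoromethyl group or an amine at this place would test whether any replacement there moves the number beyond the scatter.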